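Adding a Methoxy to Compound 3

This account rests on a few compounds, and the source may have more. Where it says the series, first, only, none or still open, it means among the compounds named here.

Measured in a physicochemical assay for lipophilicity, using the shake flask method, measured as octanol-water partition, at pH 7.4; on this read-out higher numbers stand for higher lipophilicity and lower numbers for lower lipophilicity:
- Compound 1 `COc1ccc(C2CC(=O)NCCS2)cc1`: 1.6
- Compound 2 `CCN(C)c1cc(-c2ccccc2O)nc2nccn12`: 2.9
- Compound 3 `O=C(CC1SCCNC1=O)Nc1ccccc1`: 0.8

Of these three compounds, compound 3 stands lowest. Compound 1 is its nearest neighbour and compound 2 its furthest, and both gaps lie beyond the usual scatter of repeated measurements.

The next compound to be measured is compound 4 `COc1ccccc1NC(=O)CC1SCCNC1=O`, which differs from compound 3 in one place. The difference is methoxy in place of hydrogen on an aromatic carbon in all, that is, methoxy in place of hydrogen on an aromatic carbon.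

For the measured compounds named here, no pair of measured compounds in this small set shows such a change on its own. The expectation therefore starts from compound 3 at 0.8 and rests on the structural change alone. A small upward step is expected in this assay, estimated as a number 0.30 log units higher from compound 3 to compound 4 (within the scatter) and perhaps not clearing the usual scatter. The estimate for compound 4 is 1.1 with an expected range of 0.7 to 1.5 as the likely span.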

Compound 4, distribution coefficient: 0.8
The estimate for compound 4 lay 0.30 log units above the measured number, and the stated range covers the measured number.
By their numbers in this assay, from the lowest: compounds 3 and 4 (each within the scatter of the next); then compound 1; then compound 2.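

For the compounds shown here, this is the first pair in the set that differs in one place only, so the effect of a single change can now be read directly. In this assay, methoxy in place of hydrogen on an aromatic carbon of a six-membered aromatic ring of carbon only, ortho to a large group, gives no change at the digits printed from compound 3 to compound 4 (within the scatter), so at this place the added methoxy, with its 2 heavy atoms and 1 hydrogen-bond acceptor, does not separate the two compounds on this read-out. No measurement at hand offers an explanation for this result.

This single pair covers one group at one place on one parent compound, so it cannot be extended to other compounds. It leaves open how an amine or a carboxylic acid on the same aromatic carbon would read, and whether methoxy on another carbon of that ring would read the same.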